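The compounds below may be only part of what the source reports. "The series", "measured", "known", "first", "only" and "open" are said of these compounds alone.

Among the measured compounds shown here, in a functional assay on HCT-116 cells (Homo sapiens) for cytotoxicity, read by MTT assay, with a stated time of 72 h (on this read-out higher numbers stand for weaker inhibition and lower numbers for stronger inhibition), compound 1 `CS(=O)(=O)NCCCN(c1nc(C(=O)NCc2ccc(F)cc2)c(O)c2ncccc12)S(C)(=O)=O` gives 7000 nM, the only actual number available in this small set. Compound 2 `COC(=O)CNc1c(C(=O)NCc2ccc(F)cc2)nc(Br)c2cccnc12` is recorded at > 10000 nM, which is a limit of the assay and not a number. Compound 3 `CS(=O)(=O)NCCCCCCN(c1nc(C(=O)NCc2ccc(F)cc2)c(O)c2ncccc12)S(C)(=O)=O` keeps the core of compound 1 and lengthens its chain, with 3-(methanesulfonamido)propyl in place of methanesulfonamido on a saturated chain carbon, three bonds along the chain from a sulfonamide nitrogen. For the measured compounds named here, no measured step shows what such a change does, so the only anchor is compound 1 at 7000 nM, and no change beyond the scatter is expected in this assay. The estimate amounts to an expected 1.2-fold lower number from compound 1 to compound 3 (0.07 log units; within the scatter). For compound 3 the estimated value is 6000 nM, with an expected range from 2000 nM to 13000 nM.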

Compound 3, half-maximal inhibitory concentration: 4000 nM
The estimate for compound 3 lay 1.5-fold (0.18 log units) above the measured number; the range from low to high includes it.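

In this assay, the step with 3-(methanesulfonamido)propyl in place of methanesulfonamido on a saturated chain carbon, three bonds along the chain from a sulfonamide nitrogen, reads a 1.8-fold lower number from compound 1 to compound 3 (0.24 log units; within the scatter). Among the compounds shown here, this is the first measured change at this position, and it shows that the longer chain is tolerated: the two compounds cannot be told apart in this assay, and both keep an actual number. Compound 2 differs from them in more than one place and gives no step, as its value is a limit of the assay and not a number: the limit of > 10000 nM in this assay, at which 1 of the 3 values shown sits.

On these data alone, whether a still longer chain, or an amine or a carboxylic acid in place of the methanesulfonamido, would move the number beyond the scatter remains open. The compounds shown also leave open what this change would do on the core of compound 2.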